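Tert-butyl for pyrazolyl at the hydroxyacyl chain

The source may hold more compounds than are shown below. What is called first, only, known or untested is meant among the compounds shown, and "the series" means these compounds.

Of the compounds shown here, three sharing one core have been measured in an ADME assay on Caco-2 cells (Homo sapiens) for permeability, read by LC-MS, in the apical to basolateral direction, with a stated time of 60 min, at pH 6.5; a lower number here means that the compound crosses the layer more slowly, a higher number that the compound crosses the layer faster. Compound 1 `O=C(NCc1cc(Cl)ccc1-n1cnnn1)[C@@H]1C[C@@H]2C[C@@H]2N1C(=O)[C@H](O)CC1CC1` gives 3.6 10^-6 cm/s. Compound 2 `O=C(NCc1cc(Cl)ccc1-n1cnnn1)[C@@H]1C[C@@H]2C[C@@H]2N1C(=O)[C@H](O)c1ccccc1` gives 8 10^-6 cm/s. Compound 3 `O=C(NCc1cc(Cl)ccc1-n1cnnn1)[C@@H]1C[C@@H]2C[C@@H]2N1C(=O)[C@H](O)Cn1cccn1` gives 0.45 10^-6 cm/s, the lowest of the three numbers; the step from compound 1 is an 8.0-fold lower number from compound 1 to compound 3 (0.90 log units; beyond the scatter) and that from compound 2 is an 18-fold lower number from compound 2 to compound 3 (1.25 log units; beyond the scatter). The step between the two higher compounds, a 2.2-fold higher number from compound 1 to compound 2 (0.35 log units; beyond the scatter), is smaller.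

Compound 4 `CC(C)(C)C[C@@H](O)C(=O)N1[C@H](C(=O)NCc2cc(Cl)ccc2-n2cnnn2)C[C@@H]2C[C@@H]21` has not yet been run in this assay. It differs from compound 3 as follows: tert-butyl in place of 1H-pyrazol-1-yl on a saturated chain carbon, two bonds along the chain from a carbonyl carbon and an oxygen on a saturated carbon. The change takes out the group whose arrival, in the steps from compound 1 and from compound 2 to compound 3, coincided with the two largest drops seen so far; both of those steps lie beyond the scatter. The group that enters has no ring and no acceptors, so the relevant comparison is with compound 1, whose cyclopropyl sits at the same place and whose value is 3.6 10^-6 cm/s. A step upward from compound 3 beyond the scatter is therefore expected, of a size at least comparable to the reverse of an 8.0-fold lower number from compound 1 to compound 3 (0.90 log units; beyond the scatter).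

For compound 4 the estimated number in this assay is 5 10^-6 cm/s, with a range from 2 10^-6 cm/s to 12 10^-6 cm/s, which means an expected step of an 11-fold higher number from compound 3 to compound 4 (1.05 log units; beyond the scatter).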

Compound 4, apparent permeability: 25 10^-6 cm/s
Beside the measured number, compound 4's estimate is 5.0-fold (0.70 log units) below it; the measured number lies above the stated range.
By their numbers in this assay, from the lowest: compound 3; then compound 1; then compound 2; then compound 4.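

In this assay, going by these compounds alone, the place on a saturated chain carbon, two bonds along the chain from a carbonyl carbon and an oxygen on a saturated carbon, now spans a much wider range: tert-butyl in place of 1H-pyrazol-1-yl gives a 56-fold higher number from compound 3 to compound 4 (1.74 log units; beyond the scatter), the largest step so far. Tert-butyl does more than recover the level of the cyclopropyl compound, since the same place shows a 6.9-fold higher number from compound 1 to compound 4 (0.84 log units; beyond the scatter), so compound 1 does not mark the top of what this position can give. With a 3.1-fold higher number from compound 2 to compound 4 (0.49 log units; beyond the scatter) as well, compound 4 holds the highest number of the four, and among these compounds the highest number comes from an acyclic group with no hydrogen-bond acceptors rather than from the phenyl of compound 2.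

Nothing available here gives a reason for these steps. From the compounds shown here alone, it remains open how this order would extend to a chain ending in an amine or a carboxylic acid, and whether a longer alkyl chain would continue the rise seen with neopentyl or reverse it.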